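The source may hold more compounds than are shown below. What is called first, only, known or untested is meant among the compounds shown, and "the series" means these compounds.

Measured compounds in an assay for inhibition of HSP60/HSP10 (Homo sapiens), with a stated time of 60 min; on this read-out higher numbers stand for weaker inhibition and lower numbers for stronger inhibition:

Compound 1, `COc1c(Br)cc(Br)cc1C(=O)Nc1ccccc1`, gives > 100000 nM, which is a limit of the assay and not a number.
Compound 2, `O=C(Nc1cccc(Cl)c1)c1ccccc1O`, gives > 100000 nM, again a limit and not a number.
Compound 3, `O=C(Nc1ccccc1)c1cc(Br)cc(Br)c1O`, gives 63000 nM.

Compound 3 and compound 1 differ in one place: methyl in place of hydrogen on an oxygen on an aromatic ring. In this assay this change gives an at least 1.5-fold higher number from compound 3 to compound 1 (0.20 log units; that floor lies within the scatter), and the result for compound 1 sits at the limit of > 100000 nM in this assay, at which 2 of the 3 values shown sit, so only a floor for the step is known.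

Compound 2 shares the amide link with compound 3, but how the two cores differ is not broken down here. For the measured compounds named here, compound 2 gives only a limit, so no step from compound 3 to compound 2 can be sized.

Compound 4, `COc1ccccc1C(=O)Nc1cccc(Cl)c1`, is not yet measured. It differs from compound 2 in the same way that compound 1 differs from compound 3: methyl in place of hydrogen on an oxygen on an aromatic ring. The place line reads the same in both pairs, so this is the same change, not merely the same kind.

The expectation rests on two points: compound 2 already sits at the limit, and the measured change from compound 3 to compound 1 moved the number to the limit as well. The expected step is a step that the limit leaves unreadable from compound 2 to compound 4, compared with the measured at least 1.5-fold higher number from compound 3 to compound 1 (0.20 log units; that floor lies within the scatter). For compound 4 the estimate in this assay is 150000 nM, expected to fall between 80000 nM and 400000 nM, most likely reported only as a limit.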

Compound 4, half-maximal inhibitory concentration: > 100000 nM
Compound 4 gave a limit, no number; the forecaster's own chance of this, stated with the estimate: 90%; the middle value does not contradict the limit.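

Compound 2 and compound 4 both stand as limits of the assay and not as numbers, so no step from hydroxy to methoxy can be read between them: the limit of > 100000 nM in this assay, at which 3 of the 4 values shown sit.

The compounds shown leave open whether hydroxy to methoxy changes the read-out at all on the core of compound 2, and how large the same change is on the core of compound 3.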